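Pyrrolidinyl for methoxy on the pyridyl ring of compound 2

The source may report more compounds than this note shows. Statements on the series, on what has been measured and on what is new or still open speak of the compounds shown alone.

Measured compounds:
compound 1 `NS(=O)(=O)c1cccc(-c2nc(C(c3ccc(F)cc3)c3ccc(F)cc3)sc2CC(=O)O)c1`, 140 nM
compound 2 `COc1cc(-c2nc(C(c3ccc(F)cc3)c3ccc(F)cc3)sc2CC(=O)O)ccn1`, 29 nM

Of the compounds shown here, two have been measured in an in vitro assay on HEK385-7 cells for displacement of a labelled ligand from prostaglandin D2 receptor 2 (Homo sapiens); on this read-out higher numbers stand for weaker inhibition and lower numbers for stronger inhibition. Compound 1 gives 140 nM, and compound 2 gives 29 nM. Compound 2 thus has the lower of the two numbers, and the step between them reads a 4.8-fold lower number from compound 1 to compound 2 (0.68 log units; beyond the scatter), a modest change that goes beyond the scatter.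

Compound 3 `O=C(O)Cc1sc(C(c2ccc(F)cc2)c2ccc(F)cc2)nc1-c1ccnc(N2CCCC2)c1` is not yet measured. It differs from compound 2 in one place: pyrrolidin-1-yl in place of methoxy on an aromatic carbon. Going by the values given here, the only measured step, from compound 1 to compound 2, exchanged the whole aryl group and showed a 4.8-fold lower number from compound 1 to compound 2 (0.68 log units; beyond the scatter); it bears on compound 3 only in that the pyridyl core carrying the new group is already present in compound 2. Among the compounds with values here, no measured pair speaks directly to swapping the methoxy for a pyrrolidin-1-yl group. The expectation for this assay is therefore a step that stays within the scatter, or at most a small shift in either direction.

Compound 3 is estimated at 25 nM, with a range from 8 nM to 80 nM. This estimate corresponds to a step of a 1.2-fold lower number from compound 2 to compound 3 (0.06 log units; within the scatter), expected to lie within the scatter.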

Compound 3, half-maximal inhibitory concentration: 230 nM
For compound 3 the middle estimate is 9.2-fold (0.96 log units) below the measured one; measured number outside the range, above it.
By their numbers in this assay, from the lowest: compound 2; then compounds 1 and 3 (each within the scatter of the next).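

In this assay, the place next to the ring nitrogen proves responsive: with the rest of the molecule unchanged, pyrrolidin-1-yl in place of methoxy gives a 7.9-fold higher number from compound 2 to compound 3 (0.90 log units; beyond the scatter). The advantage of compound 2 over compound 1 therefore does not come with the six-membered aromatic ring alone, since it depends on what that ring carries. With the 2-(pyrrolidin-1-yl)pyridin-4-yl group the comparison with the 3-sulfamoylphenyl group reads a 1.6-fold higher number from compound 1 to compound 3 (0.22 log units; within the scatter), so the two aryl groups cannot be told apart here. No measurement at hand explains the step between compound 2 and compound 3.

The compounds shown leave open whether the number follows the atom joined to the ring or the group as a whole, a question that an ethoxy group and a dimethylamino group at the same place would help to separate. They also leave open whether a methoxy group on another carbon of the ring would keep the number of compound 2.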